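The source may report more compounds than this note shows. Statements on the series, on what has been measured and on what is new or still open speak of the compounds shown alone.

In a functional assay on Huh-7 cells (Homo sapiens) for inhibition, read by MTT assay, with a stated time of 72 h (a lower number here means a stronger inhibitor, a higher number a weaker inhibitor), compound 3 (`Nc1nc2cc(-c3nn(CCCCCCCCCC(=O)NO)c4ncnc(N)c34)ccc2o1`) gives 41200 nM, within the usual scatter of compound 1 (`CNC(=O)CCCCCCCn1nc(-c2cnc3[nH]ccc3c2)c2c(N)ncnc21`) at 23500 nM, while compound 2 (`Nc1ncnc2c1c(-c1cnc3[nH]ccc3c1)nn2CCCCCCCCC(=O)NO`) stands clearly lower at 7380 nM. Compound 4 (`Nc1ncnc2c1c(-c1cnc3[nH]ccc3c1)nn2CCCCCCCCCC(=O)NO`) gives up the 2-amino-1,3-benzoxazol-5-yl group of compound 3 for another group on an aromatic carbon: a group of 9 heavy atoms (7 carbon, 2 nitrogen; one five-membered aromatic ring with 1 hetero atom, one six-membered aromatic ring with 1 hetero atom) in place of a group of 10 heavy atoms (7 carbon, 2 nitrogen, 1 oxygen; one five-membered aromatic ring with 2 hetero atoms, one six-membered aromatic ring of carbon only), on an aromatic carbon. Going by the values given here, no measured pair makes this swap. Among the compounds with values here, the one measured step, a 3.2-fold lower number from compound 1 to compound 2 (0.50 log units; beyond the scatter), changes the chain end instead, so it bears only indirectly. The closest guide is compound 2, at 7380 nM, which already carries the entering group, though on a chain of another length. A moderate move to a lower number is therefore expected in this assay, an estimated 3.7-fold lower number from compound 3 to compound 4 (0.57 log units; beyond the scatter). Compound 4 is estimated at 11000 nM, with an expected range of 4000 nM to 28000 nM.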

Compound 4, half-maximal inhibitory concentration: 10100 nM
For compound 4 the middle estimate is 1.1-fold (0.04 log units) above the measured one; measured number inside the range.
By their numbers in this assay, from the lowest: compounds 2 and 4 (each within the scatter of the next); then compounds 1 and 3 (each within the scatter of the next).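

With the chain held constant, the step at this aromatic carbon can now be read directly in this assay: replacing 2-amino-1,3-benzoxazol-5-yl gives a 4.1-fold lower number from compound 3 to compound 4 (0.61 log units; beyond the scatter). Placing (hydroxycarbamoyl)methyl where hydroxycarbamoyl stood gives a 1.4-fold higher number from compound 2 to compound 4 (0.14 log units; within the scatter), so these two chain lengths cannot be told apart, while 2-(hydroxycarbamoyl)ethyl in place of methylcarbamoyl gives a 2.3-fold lower number from compound 1 to compound 4 (0.37 log units; beyond the scatter). Nothing available explains these differences.

Still open, as far as these compounds go, is how a plain phenyl group on this aromatic carbon would compare. A carboxylic acid at the chain end also remains untested among these compounds.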